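From compound 2 to compound 3: acetoxymethyl on the carbonyl

The source may report more compounds than this note shows. Statements on the series, on what has been measured and on what is new or still open speak of the compounds shown alone.

In a functional assay on HeLa cells (Homo sapiens) for cytotoxicity, read by MTT assay, with a stated time of 72 h (a higher number here means a weaker inhibitor, a lower number a stronger inhibitor), compound 1 `O=C(c1ccccc1)N(/N=N/c1ccc([N+](=O)[O-])cc1Cl)c1ccc([N+](=O)[O-])cc1Cl` gives 590 nM and compound 2 `O=C(c1cccc(C(F)(F)F)c1)N(/N=N/c1ccc([N+](=O)[O-])cc1Cl)c1ccc([N+](=O)[O-])cc1Cl` gives 1180 nM. These two values lie within the scatter of each other, so compound 2 stands level with compound 1. Within the data shown here, the only measured step, a 2.0-fold higher number from compound 1 to compound 2 (0.30 log units; within the scatter), accompanies trifluoromethyl in place of hydrogen on an aromatic carbon and remains within the scatter.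

Compound 3 `CC(=O)OCC(=O)N(/N=N/c1ccc([N+](=O)[O-])cc1Cl)c1ccc([N+](=O)[O-])cc1Cl` has acetoxymethyl in place of 3-(trifluoromethyl)phenyl on a carbonyl carbon. Among the measured compounds shown here, no measured compound has a group without an aromatic ring at that carbonyl carbon, so the measured step bears on this change only indirectly. No shift beyond the scatter is therefore expected in this assay, and no direction is favoured with confidence. The expected change is a 1.3-fold lower number from compound 2 to compound 3 (0.12 log units; within the scatter). For compound 3 the estimated value is 900 nM, with an expected range of 300 nM to 2700 nM.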

Compound 3, half-maximal inhibitory concentration: 350 nM
Estimate against measurement, compound 3: 2.6-fold (0.41 log units) above; the measured number falls inside the stated range.
By their numbers in this assay, from the lowest: compounds 3, 1 and 2 (each within the scatter of the next, the first and the last beyond it).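

Carbonyl position, working notes: a group with no ring is tolerated here. In this assay, among these compounds, acetoxymethyl gives a 3.4-fold lower number from compound 2 to compound 3 (0.53 log units; beyond the scatter), the first step to lie beyond the scatter, though its size is modest. Against the phenyl group, the same change gives a 1.7-fold lower number from compound 1 to compound 3 (0.23 log units; within the scatter), which lies within the scatter, so compound 3 stands level with compound 1 and an aromatic ring on this carbonyl carbon is not needed to keep this level of cytotoxicity in this one example. No available evidence explains the result.

As far as these compounds go, it remains open whether the effect belongs to acetoxymethyl itself or simply to replacing the aromatic ring. Hydroxymethyl, a plain methyl group or a longer alkyl chain on the same carbonyl carbon would help separate these two readings.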